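The compounds below may be only part of what the source reports. "The series", "measured", "known", "first", "only" and "open" are said of these compounds alone.

Compound 1, `Cc1cc(NC(=O)Cn2nnc(-c3ccccc3)n2)n(CC2CCCCC2)n1`: 77%
Compound 2, `Cc1cc(NC(=O)Cn2nnc(-c3cccnc3)n2)n(C2CCCCC2)n1`: 96%

In an assay on HEK293 cells for activation of Kir3.1/Kir3.2 (Homo sapiens), read by thallium flux (on this read-out lower numbers stand for smaller maximal responses and higher numbers for larger maximal responses), compound 2 holds the higher of the two numbers; compound 1 sits lower, and that gap lies beyond the scatter. Compound 3, `COc1cccc(-c2nnn(CC(=O)Nc3cc(C)nn3C3CCCCC3)n2)c1`, has not been measured. It differs from compound 2 in one place: 3-methoxyphenyl in place of pyridin-3-yl on an aromatic carbon. Among the compounds with values here, no step between measured compounds that differ in one place is available, so the size of this change has no precedent here; a modest decrease, or none beyond the scatter, is expected. Compound 3 is expected to give 85%, within 65% to 100%. The step of a number 11 percentage points lower from compound 2 to compound 3 (beyond the scatter) is therefore estimated to be small.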

Compound 3, largest response reached (Emax), in percent of the reference or control that the assay uses: 76%
Estimate against measurement, compound 3: 9 percentage points above; low and high end bracket the measured number.
By their numbers in this assay, from the lowest: compounds 3 and 1 (each within the scatter of the next); then compound 2.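

In this assay, the group on the aromatic carbon between two ring nitrogen atoms affects the maximal response: 3-methoxyphenyl in place of pyridin-3-yl gives a number 20 percentage points lower from compound 2 to compound 3 (beyond the scatter). This is the only step shown in which a single place changes, so it is the first measure of a change at this position. No measurement at hand bears on why the response differs.

The change removes the ring nitrogen and adds the methoxy group at once, and the compounds shown cannot separate the two. Also open, going by these compounds, is how pyridin-4-yl or an amine would behave at this place.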